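An Ethylsulfanyl Analogue Awaiting Its Whole-Animal Result

This account rests on a few compounds, and the source may have more. Where it says the series, first, only, none or still open, it means among the compounds named here.

Measured so far:
compound 1, `CCOc1ccccc1-c1ncc(C(=O)O)c(=O)[nH]1`: 0.5 mg/kg
compound 2, `CC(C)Oc1ccccc1-c1ncc(C(=O)O)c(=O)[nH]1`: 0.8 mg/kg
compound 3, `CCOC(=O)c1cnc(-c2ccccc2SC)[nH]c1=O`: > 25 mg/kg

In a functional assay on the whole organism (strain Sprague-Dawley) for inhibition, with Rattus norvegicus as the target, with a stated time of 10 min (on this read-out higher numbers stand for an effect only at larger amounts of compound and lower numbers for an effect already at smaller amounts), compound 1 gives 0.5 mg/kg. Compound 2 gives 0.8 mg/kg in this assay. The two differ by methyl in place of hydrogen on a saturated chain carbon bound to an oxygen on an aromatic ring and a saturated chain carbon, and the step of a 1.6-fold higher number from compound 1 to compound 2 (0.20 log units; within the scatter) is within the scatter, so the two values are read as the same.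

Compound 3 is built on a different core; the difference between the cores of compound 1 and compound 3 is not broken down here. For compound 3 only a limit is known: in this assay compound 3 gives > 25 mg/kg, which is a limit of the assay and not a number (the limit of > 25 mg/kg in this assay, at which 1 of the 3 values shown sits).

Compound 4, `CCOC(=O)c1cnc(-c2ccccc2SCC)[nH]c1=O`, has not yet been measured. It differs from compound 3 by methyl in place of hydrogen on a saturated chain carbon bound to a sulfur. This is the same kind of change as that from compound 1 to compound 2, but not the same: there the carbon that receives the methyl is bound to an oxygen on an aromatic ring and a saturated chain carbon, here it is bound to a sulfur.

The step that the limit leaves unreadable from compound 3 to compound 4 is expected to be small, because the step of a 1.6-fold higher number from compound 1 to compound 2 (0.20 log units; within the scatter) was within the scatter. Compound 4 is therefore expected to give about 40 mg/kg in this assay, likely between 15 mg/kg and 120 mg/kg, and most probably again only a limit.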

Compound 4, dose for 50% inhibition: > 5 mg/kg
Compound 4: a limit, no number (the forecaster's own chance of this, stated with the estimate: 75%); the middle value lies beyond the limit too.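

In this assay compound 3 and compound 4 each give only a limit of the assay and not a number, so no step can be read between them. The compounds shown leave open whether the change from methylsulfanyl to ethylsulfanyl alters the dose needed for inhibition at all, and how large any such change would be.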